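Dioxolane Variants of a Triazole-Linked Quinone Scaffold

A few compounds are considered here, and "the series" means these few. Any claim that something is new, unique, unknown or untested is made for them only; others in the source may bear on it.

The series rests on a shared core carried through three compounds. Compound 1 `CC1(C)O[C@@H](CO)[C@H](Cn2cc(Cn3c4c(c5ccccc53)C(=O)c3c[n+]([O-])c5ccccc5c3C4=O)nn2)O1` bears a (5-(hydroxymethyl)-2,2-dimethyl-1,3-dioxolan-4-yl)methyl group on the triazole nitrogen; in a functional assay on SH-SY5Y cells (Homo sapiens) for cytotoxicity, read by MTT assay, with a stated time of 72 h (on this read-out higher numbers stand for weaker inhibition and lower numbers for stronger inhibition), compound 1 gives only a limit, > 1000 nM, and not a number. Among the measured compounds shown here, compound 2 `O=C1c2c[n+]([O-])c3ccccc3c2C(=O)c2c1c1ccccc1n2Cc1cn([C@H]2O[C@H](CO)[C@@H](O)[C@H]2O)nn1` carries a 3,4-dihydroxy-5-(hydroxymethyl)oxolan-2-yl group in the same place, and in this assay compound 2 gives 1340 nM, the only measured number in the set. For compound 1 the value is a limit (the limit of > 1000 nM in this assay, at which 1 of the 2 values shown sits). The step that the limit leaves unreadable from compound 1 to compound 2 therefore cannot be sized.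

Compound 3 `CC1(C)OC[C@H](Cn2cc(Cn3c4c(c5ccccc53)C(=O)c3c[n+]([O-])c5ccccc5c3C4=O)nn2)O1` differs from compound 2 by the change ((2,2-dimethyl-1,3-dioxolan-4-yl)methyl in place of 3,4-dihydroxy-5-(hydroxymethyl)oxolan-2-yl on an aromatic nitrogen). For the measured compounds named here, no measured step bears on this change in a readable way, since the one step in the set is obscured by the limit. The expectation for compound 3 is therefore anchored on compound 2 alone, with a step of a 1.1-fold higher number from compound 2 to compound 3 (0.05 log units; within the scatter) that is not expected to exceed the scatter. Compound 3 is thus estimated at 1500 nM, within a range from 700 nM to 4000 nM.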

Compound 3, half-maximal inhibitory concentration: 820 nM
For compound 3 the middle estimate is 1.8-fold (0.26 log units) above the measured one; the measured number falls inside the stated range.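

In this assay, (2,2-dimethyl-1,3-dioxolan-4-yl)methyl, with 0 hydrogen-bond donors, in place of 3,4-dihydroxy-5-(hydroxymethyl)oxolan-2-yl, with 3 hydrogen-bond donors, on the aromatic nitrogen gives a 1.6-fold lower number from compound 2 to compound 3 (0.21 log units; within the scatter), so this large exchange of groups leaves compound 2 and compound 3 indistinguishable on this read-out. Hydrogen in place of hydroxymethyl on a saturated ring carbon of the dioxolane group gives an at least 1.2-fold lower number from compound 1 to compound 3 (0.08 log units; that floor lies within the scatter), and this floor does not establish that the hydroxymethyl group makes any difference. The value of compound 1 remains a limit and not a number, and the step from compound 1 to compound 2 cannot be read: the limit of > 1000 nM in this assay, at which 1 of the 3 values shown sits.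

As far as these compounds go, whether an amine, a carboxylic acid or a longer alkyl chain on this aromatic nitrogen would give a step beyond the scatter remains open, for every step that can be read here stays within it or has only a floor within it. Also open, from the compounds shown here alone, is whether the defined stereocentre of the (2,2-dimethyl-1,3-dioxolan-4-yl)methyl group has any bearing on the number.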